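The source may report more compounds than this note shows. Statements on the series, on what has been measured and on what is new or still open speak of the compounds shown alone.

Measured in a toxicity assay on HepG2 2.2.15 cells (Homo sapiens) for cytotoxicity, read by CellTiter-Glo; on this read-out higher numbers stand for lower toxicity in this test and lower numbers for higher toxicity in this test:
compound 1 `O=C(Nc1cc(F)c(F)c(F)c1)N1Cc2c(-c3ccc(F)cc3F)cnn2CC1C1CC1` gives 32100 nM
compound 2 `Cc1cnc(C2CC(=O)N(c3cnn4c3CN(C(=O)Nc3cc(F)c(F)c(F)c3)C(C3CC3)C4)C2)s1` gives 96200 nM

Compound 1 holds the lowest of these two numbers; its nearest neighbour is compound 2, reached by a 3.0-fold higher number from compound 1 to compound 2 (0.48 log units; beyond the scatter), a modest step through replacement of the 2,4-difluorophenyl group by 4-(5-methyl-1,3-thiazol-2-yl)-2-oxopyrrolidin-1-yl.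

Compound 3 `O=C1CC(c2ccccc2)CN1c1cnn2c1CN(C(=O)Nc1cc(F)c(F)c(F)c1)C(C1CC1)C2` differs from compound 1 as follows: 2-oxo-4-phenylpyrrolidin-1-yl in place of 2,4-difluorophenyl on an aromatic carbon. Going by the values given here, this is the one measured step that bears on it, since the same 2,4-difluorophenyl group leaves the same aromatic carbon and an oxopyrrolidinyl group enters, here carrying phenyl rather than the thiazolyl substituent. A step of similar size and the same direction is therefore expected in this assay: a 2.2-fold higher number from compound 1 to compound 3 (0.34 log units; beyond the scatter). Compound 3 is accordingly estimated at 70000 nM, with a range from 30000 nM to 160000 nM.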

Compound 3, half-maximal cytotoxic concentration: 12800 nM
Compound 3: middle estimate off by 5.5-fold (0.74 log units), on the high side; measured number outside the range, below it.
By their numbers in this assay, from the lowest: compound 3; then compound 1; then compound 2.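

In this assay, swapping the 2,4-difluorophenyl group for an oxopyrrolidinyl group at this aromatic carbon has no fixed direction: the 2-oxo-4-phenylpyrrolidin-1-yl group gives a step (a 2.5-fold lower number from compound 1 to compound 3 (0.40 log units; beyond the scatter)) opposite to the earlier one with the thiazolyl-bearing group (a 3.0-fold higher number from compound 1 to compound 2 (0.48 log units; beyond the scatter)). Within these three compounds, the substituent on the saturated ring carbon of the oxopyrrolidinyl group therefore sets the direction, and phenyl in place of 5-methyl-1,3-thiazol-2-yl gives the largest step seen so far (a 7.5-fold lower number from compound 2 to compound 3 (0.88 log units; beyond the scatter)). Nothing available explains this reversal.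

From the compounds shown here alone, it remains open where the unsubstituted 2-oxopyrrolidin-1-yl group would fall relative to compound 1. Also open, going by these compounds, is whether a pyridyl or a dimethylamino group on that saturated ring carbon would lie nearer compound 2 or compound 3.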